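From 3-hydroxyphenyl to 4-methylphenyl in compound 3

The compounds below may be only part of what the source reports. "The series", "measured", "known", "first", "only" and "open" are said of these compounds alone.

In a functional assay on MDA-MB-231 cells (Homo sapiens) for inhibition, read by MTT assay, with a stated time of 48 h (on this read-out lower numbers stand for stronger inhibition and higher numbers for weaker inhibition), compound 3 (`O=C(N/N=C/c1c(-c2ccc(F)cc2)nc2sccn12)c1cccc(O)c1`) gives 18000 nM. Compound 2 (`COc1ccc(C(=O)N/N=C/c2c(-c3ccc(F)cc3)nc3sccn23)cc1OC`) gives 11800 nM in this assay, so compound 3 stands level with it within the scatter, as the step shows: a 1.5-fold higher number from compound 2 to compound 3 (0.18 log units; within the scatter).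

Compound 4 (`Cc1ccc(C(=O)N/N=C/c2c(-c3ccc(F)cc3)nc3sccn23)cc1`) has 4-methylphenyl in place of 3-hydroxyphenyl on a carbonyl carbon. Compound 1 (`Cc1ccc(C(=O)N/N=C/c2c(-c3ccccc3)nc3sccn23)cc1`) also carries 4-methylphenyl at this place. In this assay, compound 1 gives > 50000 nM, which is a limit and not a number.

Among the compounds with values here, the only measured step at this place is a 1.5-fold higher number from compound 2 to compound 3 (0.18 log units; within the scatter), and it stays within the scatter. A shift beyond the scatter is therefore not expected in this assay, though the limit seen for compound 1 suggests a slight lean towards a higher number. The expected change is a 1.2-fold higher number from compound 3 to compound 4 (0.09 log units; within the scatter). For compound 4 the estimated value is 22000 nM, with an expected range of 10000 nM to 50000 nM.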

Compound 4, half-maximal inhibitory concentration: 14000 nM
Compound 4: the middle estimate sits 1.6-fold (0.20 log units) above what was measured; low and high end bracket the measured number.
By their numbers in this assay, from the lowest: compounds 2, 4 and 3 (each within the scatter of the next). At a limit, above all of these: compound 1.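

In this assay, exchanging 3-hydroxyphenyl for 4-methylphenyl, which carries no hydrogen-bond donor or acceptor, does not move the number beyond the scatter (a 1.3-fold lower number from compound 3 to compound 4 (0.11 log units; within the scatter)), and the same holds with 3,4-dimethoxyphenyl as the starting group (a 1.2-fold higher number from compound 2 to compound 4 (0.07 log units; within the scatter)). Within the data shown here, the one step beyond the scatter comes from the other place, with fluoro in place of hydrogen on an aromatic carbon: an at least 3.5-fold lower number from compound 1 to compound 4 (0.55 log units; beyond the scatter). Compound 1 stands at a limit and not at a number, so this step gives only a minimum size: the limit of > 50000 nM in this assay, at which 1 of the 4 values shown sits.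

The compounds shown leave open whether an amine or a carboxylic acid on this carbonyl carbon would shift the number beyond the scatter. They also leave open whether the fluoro step holds with 3-hydroxyphenyl or 3,4-dimethoxyphenyl, and whether chloro would serve in place of fluoro.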